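A few compounds are considered here, and "the series" means these few. Any claim that something is new, unique, unknown or untested is made for them only; others in the source may bear on it.

Measured compounds:
compound 1 `CCc1ccc(NC(=O)Nc2cc(C)nc3ccccc23)cc1`: > 25000 nM, a limit of the assay
compound 2 `Cc1cc(NC(=O)Nc2ccccc2C(C)(C)C)c2ccccc2n1`: 22000 nM
compound 3 `Cc1cc(NC(=O)Nc2ccc([N+](=O)[O-])c(C(F)(F)F)c2)c2ccccc2n1`: > 25000 nM, a limit of the assay

In an ADME assay on BJ cells (Homo sapiens) for cytotoxicity, with a stated time of 72 h (a higher number here means that more compound is needed for the effect, a lower number that less compound is needed), compound 1 stands only at a limit, > 25000 nM, not at a number. Compound 3 is likewise reported only as a limit, > 25000 nM. Compound 2 alone gives a number, 22000 nM, and that number is high; the series sits at the limit of > 25000 nM in this assay, at which 2 of the 3 values shown sit. Compound 4 `Cc1cc(NC(=O)Nc2ccc(N)cc2)c2ccccc2n1` keeps the core of compound 1 with amino in place of ethyl on an aromatic carbon. Within the data shown here, no step between measured compounds is available, so nothing measured shows what this change does to cytotoxicity. With every value shown at or near the limit, no step beyond the scatter is expected. Compound 4 is expected to give 25000 nM, between 10000 nM and 60000 nM, most likely again only as a limit. The step is expected to be a number no higher from compound 1 to compound 4 (the limit leaves the size open).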

Compound 4, half-maximal effective concentration: > 25000 nM
Compound 4: a limit, no number; the forecaster's own chance of this, stated with the estimate: 70%; the middle value lies on the limit itself.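

Among these compounds, compound 1 and compound 4 are both reported only as limits, so no step between them can be read. The compounds shown leave open whether amino in place of ethyl on an aromatic carbon shifts the read-out in this assay at all.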